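This account rests on a few compounds, and the source may have more. Where it says the series, first, only, none or still open, it means among the compounds named here.

Measured so far:
compound 1 `Cc1nc(N)sc1CCCN/C(N)=N/C(=O)N[C@H](C)c1ccccc1` — 17.8 nM
compound 2 `Cc1nc(N)sc1CCCN/C(N)=N/C(=O)NC(c1ccccc1)c1ccccc1` — 43.7 nM
compound 3 `CCCCCCNC(=O)/N=C(\N)NC1CCc2nc(N)sc2C1` — 1120 nM

All three numbers come from an assay on membranes from Sf9 cells for displacement of a labelled ligand from histamine H2 receptor (Homo sapiens), read by scintillation counting, with a stated time of 60 min; on this read-out higher numbers stand for weaker inhibition and lower numbers for stronger inhibition. Compound 1 stands lowest of the three. Its nearest neighbour is compound 2, which lies beyond the scatter above it; compound 3 lies far beyond it, the widest gap in the set. The shared core of compound 1 and compound 2 carries the acylguanidine chain, and compound 3 holds a different arrangement with a hexyl chain on the urea nitrogen.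

The next compound is compound 4 `Cc1nc(N)sc1CCCN/C(N)=N/C(=O)Nc1ccccc1`. Relative to compound 1 it shows (phenyl in place of 1-phenylethyl on an amide-type nitrogen). Among the measured compounds shown here, no measured pair isolates this change, so the size of the step rests on judgement. The other substitution on this nitrogen in hand, compound 2, gives 43.7 nM, so a change of the group on this nitrogen need not move the number far. A modest step towards a higher number, possibly within the scatter, is expected from compound 1 to compound 4, a 2.2-fold higher number from compound 1 to compound 4 (0.35 log units; beyond the scatter). Compound 4 is therefore estimated at 40 nM, within a range from 12 nM to 150 nM, to be checked in this assay.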

Compound 4, inhibition constant: 3160 nM
Beside the measured number, compound 4's estimate is 79-fold (1.90 log units) below it, and the stated range ends below it.
By their numbers in this assay, from the lowest: compound 1; then compound 2; then compound 3; then compound 4.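

In this assay, the group on the amide-type nitrogen proves decisive: phenyl in place of 1-phenylethyl gives a 180-fold higher number from compound 1 to compound 4 (2.25 log units; beyond the scatter). Compound 1 and compound 2 at 43.7 nM both hold their aromatic rings on a carbon attached to this nitrogen, so together they showed only that this arrangement accepts more than one group, whereas compound 4, with its ring attached directly to the nitrogen, shows that keeping an aromatic ring here is not enough to preserve the low number. The change removes a defined stereocentre along with the linking carbons, a single step cannot separate these two differences, and no measurement at hand explains the size of the step.

Still open, as far as these compounds go, is where a benzyl group or a longer chain such as 2-phenylethyl on this nitrogen would fall relative to compound 1 and compound 4, which would show how much of the step follows the linking carbon and how much the methyl branch. The compounds shown also leave open how the opposite enantiomer of the 1-phenylethyl group compares with compound 1.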